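The source may report more compounds than this note shows. Statements on the series, on what has been measured and on what is new or still open speak of the compounds shown alone.

Two compounds with a five-membered aromatic ring that holds one nitrogen and one sulfur open the set. Compound 1, `CCn1sc(Cl)cc1=O`, is tested in an assay on isolated protein for inhibition of histone acetyltransferase KAT2B (Homo sapiens), read by fluorescence, with a stated time of 15 min (on this read-out higher numbers stand for weaker inhibition and lower numbers for stronger inhibition), and in this assay compound 1 gives 3000 nM. Compound 2, `CCn1sc(Cl)c(Cl)c1=O`, differs from it in one place: chloro in place of hydrogen on an aromatic carbon. In this assay compound 2 gives 2400 nM. The step of a 1.3-fold lower number from compound 1 to compound 2 (0.10 log units; within the scatter) is therefore small.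

A differently built core follows. Compound 3, `CCCCCCCCCCCCSc1cc(=O)n(CCC(=O)OC)[s+]1[O-]`, carries a 2-(methoxycarbonyl)ethyl group on the ring nitrogen and an oxygen on the ring sulfur; how its core differs from that of compound 1 is not broken down here. In this assay compound 3 reaches only a limit of the measurement, > 10000 nM, so no true number is known for it. For the measured compounds named here, that limit, (the limit of > 10000 nM in this assay, at which 1 of the 3 values shown sits), is the only information on this core so far.

Compound 4, `CCCCCCCCCCCCSc1c(Cl)c(=O)n(CCC(=O)OC)[s+]1[O-]`, is the unmeasured partner of compound 3: chloro in place of hydrogen on an aromatic carbon. This is the same kind of change as between compound 1 and compound 2, though the surroundings differ. Here the chloro sits next to the ring atom that bears a large group and two ring bonds from the ring atom that bears a 2-(methoxycarbonyl)ethyl group, whereas in compound 2 it sits next to the ring atom that bears a chloro group and two ring bonds from the ring atom that bears an ethyl group. Because the step of a 1.3-fold lower number from compound 1 to compound 2 (0.10 log units; within the scatter) stays within the scatter, an equally modest step is expected, a step that the limit leaves unreadable from compound 3 to compound 4. Since compound 3 rests at the limit (the limit of > 10000 nM in this assay, at which 1 of the 3 values shown sits), compound 4 is expected to give 12000 nM, most likely again only a limit, with a plausible range from 5000 nM to 30000 nM.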

Compound 4, half-maximal inhibitory concentration: > 10000 nM
Compound 4 ended at the assay's limit; the forecaster's own chance of this, stated with the estimate: 80%; the middle value is on the limit's open side.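

In this assay compound 4 gives > 10000 nM as a limit and not a number. For the compounds shown here, compound 3 stands at the same limit, so no step from compound 3 to compound 4 can be read, and the result comes down to this: the limit of > 10000 nM in this assay, at which 2 of the 4 values shown sit. The compounds shown leave open what chloro in place of hydrogen does on this core, since neither compound has a true number.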